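From compound 3 to compound 4: a level series

This account rests on a few compounds, and the source may have more. Where it says the series, first, only, none or still open, it means among the compounds named here.

In a functional assay on MCF7 cells (Homo sapiens) for cytotoxicity, read by MTT assay, with a stated time of 72 h (a higher number here means a weaker inhibitor, a lower number a stronger inhibitor), compound 1 (`COc1ccc(/C=C2\CCC/C(=C\c3cccc(OC)c3OC)C2=O)cc1OC`) gives 6500 nM. Compound 2 (`COc1ccc(/C=C2\CCC/C(=C\c3cccc(Cl)c3)C2=O)cc1OC`) gives 6000 nM. Compound 3 (`COc1ccc(/C=C2\CCC/C(=C\c3ccc(Br)cc3)C2=O)cc1OC`) gives 6900 nM. All three numbers lie within the scatter of one another, so compound 3 stands level with compound 1 and compound 2, and no order can be read among them.

The next compound is compound 4 (`COc1ccccc1/C=C1\CCC/C(=C\c2ccc(OC)c(OC)c2)C1=O`). The structural change leading to it is 2-methoxyphenyl in place of 4-bromophenyl on a double-bonded chain carbon bound to a double-bonded ring carbon. Among the measured compounds shown here, the 2-methoxyphenyl group itself appears in no measured step, and this is the main gap in the notes.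

For the measured compounds named here, only one measured step bears on this place: a 1.2-fold higher number from compound 2 to compound 3 (0.06 log units; within the scatter). That exchange of 3-chlorophenyl for 4-bromophenyl on a double-bonded chain carbon bound to a double-bonded ring carbon stays within the scatter. Compound 1, at 6500 nM, also stays level with compound 3. On this small evidence, no step beyond the scatter is expected in this assay, and no direction can be argued. The expected change is a 1.1-fold lower number from compound 3 to compound 4 (0.03 log units; within the scatter), which is no real shift. Compound 4 is estimated at 6500 nM, with an expected range of 3500 nM to 12000 nM.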

Compound 4, half-maximal inhibitory concentration: 8000 nM
Compound 4: the middle estimate sits 1.2-fold (0.09 log units) below what was measured; measured number inside the range.
By their numbers in this assay, from the lowest: compounds 2, 1, 3 and 4 (each within the scatter of the next).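

In this assay the 2-methoxyphenyl group on a double-bonded chain carbon bound to a double-bonded ring carbon gives a 1.2-fold higher number from compound 3 to compound 4 (0.06 log units; within the scatter) and a 1.3-fold higher number from compound 2 to compound 4 (0.12 log units; within the scatter) as well, so a group with one hydrogen-bond acceptor stands level with 4-bromophenyl and 3-chlorophenyl, which have none. Compound 4 also opens a second kind of comparison, with hydrogen in place of methoxy on an aromatic carbon, and a 1.2-fold higher number from compound 1 to compound 4 (0.09 log units; within the scatter) shows that this exchange also stays within the scatter. No measurement is available that could explain why the series stays level at this place.

As far as these compounds go, every group seen so far at this place is a substituted phenyl, so it remains open whether a carboxylic acid, an amine or a longer chain there would stay level in this assay or move the number beyond the scatter. From the compounds shown here alone, it also remains open whether any change to the shared core itself, rather than to this group, would produce a step beyond the scatter.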